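Adding a Methoxy Group Where the Chloro Stood

The source may hold more compounds than are shown below. What is called first, only, known or untested is meant among the compounds shown, and "the series" means these compounds.

Going by the values given here, in a functional assay on cells (Lymphocyte) (a lower number here means a stronger inhibitor, a higher number a weaker inhibitor), compound 1 `Nc1nc(N2CCN(C(=O)COc3ccc(Cl)cc3)CC2)c2ccsc2n1` gives 330 nM, and compound 2 `Nc1nc(N2CCN(C(=O)COc3ccccc3)CC2)c2ccsc2n1` gives 780 nM, the higher of the two numbers measured so far. Among the compounds with values here, the one measured step, a 2.4-fold higher number from compound 1 to compound 2 (0.37 log units; beyond the scatter), bears directly on the change followed here. Compound 3 `COc1ccc(OCC(=O)N2CCN(c3nc(N)nc4sccc34)CC2)cc1` differs from compound 2 by methoxy in place of hydrogen on an aromatic carbon. Because removing the chloro raised the number in a 2.4-fold higher number from compound 1 to compound 2 (0.37 log units; beyond the scatter), putting a different group back in that place may lower it again, though by an uncertain amount. Compound 3 is expected to give 500 nM, within 200 nM to 1200 nM. That estimate means a 1.6-fold lower number from compound 2 to compound 3 (0.19 log units; within the scatter), a modest step expected downward.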

Compound 3, half-maximal inhibitory concentration: 72 nM
Compound 3: the middle estimate sits 6.9-fold (0.84 log units) above what was measured, and the stated range ends above it.
By their numbers in this assay, from the lowest: compound 3; then compound 1; then compound 2.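

The ring carbon para to a large group matters more than the chloro step suggested: in this assay methoxy in place of hydrogen gives an 11-fold lower number from compound 2 to compound 3 (1.03 log units; beyond the scatter) and is a large step. Methoxy also outdoes chloro at this place, with a 4.6-fold lower number from compound 1 to compound 3 (0.66 log units; beyond the scatter) beyond the scatter, so the gain is more than simply having some group there. Nothing available explains why methoxy does better here.

From the compounds shown here alone, whether ethoxy, with its longer chain, or an amine at this place would lower the number further remains open. So does whether methoxy elsewhere on the ring would give a similar step.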